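Amino in place of methyl: what to expect

The source may report more compounds than this note shows. Statements on the series, on what has been measured and on what is new or still open speak of the compounds shown alone.

- Compound 1 `Cc1nnc(Sc2coc3ccccc3c2=O)o1`: > 50000 nM (a limit)
- Compound 2 `Cc1nnc(Sc2coc3ccccc3c2=O)s1`: 40200 nM

For the measured compounds named here, in a functional assay on HEp-2 cells (Homo sapiens) for antiproliferative activity, read by MTT assay, with a stated time of 72 h (a lower number here means a stronger inhibitor, a higher number a weaker inhibitor), compound 2 gives 40200 nM, the only exact number so far. Compound 1 shows > 50000 nM, which is a limit of the assay and not a number. Compound 3 `Nc1nnc(Sc2coc3ccccc3c2=O)s1` is the next to be tested, and its change is amino in place of methyl on an aromatic carbon. Going by the values given here, the one measured step, an at least 1.2-fold lower number from compound 1 to compound 2 (0.09 log units; that floor lies within the scatter), involves a different change, and no measured step involves this one. A small step with no firm direction is therefore expected. The expected step is a 1.3-fold lower number from compound 2 to compound 3 (0.10 log units; within the scatter). The estimate for compound 3 is 32000 nM, with an expected range of 11000 nM to 50000 nM.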

Compound 3, half-maximal inhibitory concentration: 47700 nM
Beside the measured number, compound 3's estimate is 1.5-fold (0.17 log units) below it; the range from low to high includes it.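

In this assay, amino in place of methyl gives a 1.2-fold higher number from compound 2 to compound 3 (0.07 log units; within the scatter), so this first change at this position on the five-membered aromatic ring leaves the number where it was. Replacing the whole group on the sulfur gives an at least 1.0-fold lower number from compound 1 to compound 3 (0.02 log units; that floor lies within the scatter), a floor that sets no order. The value of compound 1 is a limit of the assay and not a number: the limit of > 50000 nM in this assay, at which 1 of the 3 values shown sits.

Going by these compounds, whether a carboxylic acid or a longer alkyl chain at this position would move the number beyond the scatter remains open.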